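Benzylthio nucleosides: nitro in place of iodo on the phenyl ring

The source may hold more compounds than are shown below. What is called first, only, known or untested is meant among the compounds shown, and "the series" means these compounds.

compound 1 `OC[C@H]1O[C@@H](n2cnc3c(SCc4ccc(Br)cc4)ncnc32)[C@H](O)[C@@H]1O`: 11.5 nM
compound 2 `OC[C@H]1O[C@@H](n2cnc3c(SCc4ccccc4I)ncnc32)[C@H](O)[C@@H]1O`: 19.5 nM

In an assay on isolated protein for inhibition of Equilibrative nucleoside transporter 1 (Homo sapiens) (a lower number here means a stronger inhibitor, a higher number a weaker inhibitor), compound 1 gives 11.5 nM and compound 2 gives 19.5 nM. For the measured compounds named here, the only measured step, a 1.7-fold higher number from compound 1 to compound 2 (0.23 log units; within the scatter), lies within the scatter, so compound 2 is not separated from compound 1 on these numbers. Compound 3 `O=[N+]([O-])c1ccccc1CSc1ncnc2c1ncn2[C@@H]1O[C@H](CO)[C@@H](O)[C@H]1O` differs from compound 2 by nitro in place of iodo on an aromatic carbon. Going by the values given here, no measured step exchanges iodo for nitro; the single step available in this assay changed the number little, so no movement beyond the scatter is expected. The expected step is a 1.3-fold higher number from compound 2 to compound 3 (0.11 log units; within the scatter). Compound 3 is estimated at 25 nM, with a range of 8 nM to 80 nM.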

Compound 3, inhibition constant: 115 nM
Beside the measured number, compound 3's estimate is 4.6-fold (0.66 log units) below it, outside the stated range (above it).
By their numbers in this assay, from the lowest: compounds 1 and 2 (each within the scatter of the next); then compound 3.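

In this assay, for the compounds shown here, the aromatic carbon bearing iodo in compound 2 does not tolerate every group alike: nitro there gives a 5.9-fold higher number from compound 2 to compound 3 (0.77 log units; beyond the scatter) and is the first step beyond the scatter. Set against the 4-bromophenyl of compound 1, 2-nitrophenyl gives a 10-fold higher number from compound 1 to compound 3 (1.00 log units; beyond the scatter) even though compound 1 and compound 2 are not separated. Nothing available explains this weakening. Still open, going by these compounds, is whether the weakening is specific to nitro or extends to other groups on this carbon, such as an amine, a carboxylic acid or methoxy.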